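The source may report more compounds than this note shows. Statements on the series, on what has been measured and on what is new or still open speak of the compounds shown alone.

Of the compounds shown here, three have been measured in a physicochemical assay for lipophilicity, read by HPLC, at pH 7.4; a higher number here means a more lipophilic compound, a lower number a more polar compound. Compound 1 `Cc1ccc([C@@H](C)Oc2cc3onc(CCC(=O)O)c3cc2Cl)nc1` gives 2.42, compound 2 `C[C@@H](Oc1cc2onc(CCC(=O)O)c2cc1Cl)c1ccc(F)cn1` gives 2.47, and compound 3 `O=C(O)CCn1c(=O)oc2cc(OCc3ccccc3)c(Cl)cc21` gives 2.71. Compound 3 has the highest of the three numbers, yet its gap to compound 2 and its gap to compound 1 both lie within the scatter, so the three stand level. Going by the values given here, the single measured step, a number 0.05 log units higher from compound 1 to compound 2 (within the scatter), also stays within the scatter.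

Compound 4 `CC(C)Cc1cc2oc(=O)n(CCC(=O)O)c2cc1Cl` differs from compound 3 in one place: isobutyl in place of benzyloxy on an aromatic carbon. The change removes the benzyloxy group, with its single hydrogen-bond acceptor, and brings in a chain of four carbons without ring or acceptor. Among the compounds with values here, no measured step touches such a change; the step from compound 1 to compound 2 concerns a fluoro in place of a methyl and offers no guide here. On the structural change alone, a modest rise in this assay is expected for compound 4, of about a number 0.19 log units higher from compound 3 to compound 4 (within the scatter). The estimate for compound 4 is therefore 2.9, within a range from 2.4 to 3.4.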

Compound 4, distribution coefficient: 3.03
Compound 4: the middle estimate sits 0.13 log units below what was measured, within the range that was stated.
By their numbers in this assay, from the lowest: compounds 1, 2 and 3 (each within the scatter of the next); then compound 4.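

Isobutyl in place of benzyloxy, on an aromatic carbon ortho to a chloro group, gives a number 0.32 log units higher from compound 3 to compound 4 (beyond the scatter) in this assay, the first step shown that lies beyond the scatter. It shows that the group on this carbon can move the number, and that here a group of 4 heavy atoms with no ring gives a higher reading than one of 8 heavy atoms with an aromatic ring. Nothing measured alongside this result accounts for the rise.

This single pair cannot separate the loss of the ether oxygen from the loss of the ring or the arrival of the branched chain. A benzyl group on this carbon, which keeps the ring without the oxygen, and a straight butyl chain, which has no branch, would help tell these apart.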